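The source may report more compounds than this note shows. Statements on the series, on what has been measured and on what is new or still open speak of the compounds shown alone.

Working notes on the thiourea ester series.

Two compounds have numbers in an assay on HEK-Blue hTLR2 cells for agonist activity at Toll-like receptor 2 (Homo sapiens), with a stated time of 24 h; on this read-out lower numbers stand for an effect already at smaller amounts and higher numbers for an effect only at larger amounts of compound. Compound 1 `COC(=O)c1c(NC(=S)Nc2cccc3ccccc23)sc2c1CCC2` gives 3570 nM in this assay. Compound 2 `CC(C)OC(=O)c1c(NC(=S)Nc2cccc3ccccc23)sc2c1CCCC2` gives 140 nM in this assay. Compound 1 thus stands at the highest of the two numbers, with compound 2 the nearest neighbour at a markedly lower number, a gap well beyond the usual scatter. For the measured compounds named here, compound 2 is not a single-change neighbour of compound 1, so no step between the two can be read off; only their two values stand.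

Compound 3 `CC(C)COC(=O)c1c(NC(=S)Nc2cccc3ccccc23)sc2c1CCC2` is the next member. It differs from compound 1 by isopropyl in place of hydrogen on a saturated chain carbon bound to an oxygen next to a carbonyl group, so the methoxycarbonyl group becomes an isobutoxycarbonyl group on the shared core of compound 1. Going by the values given here, no single-change step exists to size this move. A larger ester is present in compound 2, whose value in this assay is 140 nM, so the expectation is a move toward lower numbers, moderate in size and not firmly beyond the scatter. Compound 3 is expected at 800 nM, within a range from 200 nM to 3200 nM. The estimated step of a 4.5-fold lower number from compound 1 to compound 3 (0.65 log units; beyond the scatter) is a downward one.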

Compound 3, half-maximal effective concentration: 28200 nM
Beside the measured number, compound 3's estimate is 35-fold (1.55 log units) below it; the whole stated range lies below it.
By their numbers in this assay, from the lowest: compound 2; then compound 1; then compound 3.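

In this assay the ester position now has its first sized step: isopropyl in place of hydrogen on a saturated chain carbon bound to an oxygen next to a carbonyl group, turning methoxycarbonyl into isobutoxycarbonyl, gives a 7.9-fold higher number from compound 1 to compound 3 (0.90 log units; beyond the scatter). On the shared core of compound 1, this position therefore responds to the change, and the isobutoxycarbonyl group goes with a higher number, not a lower one. The low value of compound 2 cannot be credited to its ester alone, since compound 2 differs from each of the other two compounds in more than one place and its steps cannot be read, and no measurement at hand bears on why the number moves this way.

Still open, going by these compounds, is whether the rise belongs to the branching of the isobutyl chain or to chain length as such, which a straight ethyl or butyl ester on the same core would separate. Also open, on these data alone, are whether the same change on the core of compound 2 would run in the same direction, and whether a carboxylic acid or an amide in place of the ester would keep any effect.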